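The source may hold more compounds than are shown below. What is called first, only, known or untested is meant among the compounds shown, and "the series" means these compounds.

Measured: compound 1 `Cc1ccccc1/C(CCN1CCN(c2ccccn2)CC1)=N/O` with 4.2 nM; compound 2 `Cc1ccccc1/C(CCN1CCN(c2ccccn2)CC1)=N\O` with 20.3 nM.

In a functional assay on HEK293 cells with D(4) dopamine receptor (Homo sapiens) as the target, read by FLIPR (on this read-out higher numbers stand for an effect only at larger amounts of compound and lower numbers for an effect already at smaller amounts), compound 2 gives 20.3 nM, the highest of the two numbers; compound 1 gives 4.2 nM. The step of a 4.8-fold higher number from compound 1 to compound 2 (0.68 log units; beyond the scatter) rests on configuration alone (the fact that compounds 1 and 2 differ only in the configuration as drawn). Compound 3 `O/N=C(/CCN1CCN(c2ccccn2)CC1)c1cc(F)cc(F)c1` differs from compound 2 by 3,5-difluorophenyl in place of 2-methylphenyl on a carbon with a double bond to nitrogen. For the measured compounds named here, no measured step concerns an aryl replacement of this kind, so the single measured step offers no guidance for the change. Compound 3 is therefore estimated near compound 2, at 20 nM, within 4 nM to 100 nM. The expected step of a 1.0-fold lower number from compound 2 to compound 3 (0.01 log units; within the scatter) is not beyond the scatter, with wide uncertainty.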

Compound 3, half-maximal effective concentration: 17.5 nM
The estimate for compound 3 lay 1.1-fold (0.06 log units) above the measured number; the range from low to high includes it.
By their numbers in this assay, from the lowest: compound 1; then compounds 3 and 2 (each within the scatter of the next).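

In this assay, for the compounds shown here, the change at the carbon with a double bond to nitrogen is the first aryl replacement, and it gives a 1.2-fold lower number from compound 2 to compound 3 (0.06 log units; within the scatter). Methyl on the ring can thus give way to two fluorines in this configuration without a change beyond the scatter, whereas a 4.8-fold higher number from compound 1 to compound 2 (0.68 log units; beyond the scatter) remains the only step beyond it. Nothing at hand accounts for the aryl step.

Open, going by these compounds, is whether 3,5-difluorophenyl shows a configuration step like that of 2-methylphenyl. Also open, on these data alone, is how an unsubstituted phenyl, a methoxyphenyl or a longer chain would read here.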